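Turning a ring stereocentre in a sigma-1 ligand

The source may report more compounds than this note shows. Statements on the series, on what has been measured and on what is new or still open speak of the compounds shown alone.

Compound 1 `NCC[C@@H]1CCC[C@H](c2ccccc2)C1` stands as the highest of the two numbers measured in an assay on membranes from brain for displacement of a labelled ligand from Sigma non-opioid intracellular receptor 1 (Cavia porcellus), read by scintillation counting, with a stated time of 120 min (a lower number here means a stronger inhibitor, a higher number a weaker inhibitor), where compound 1 gives 167 nM. Compound 2 `CN(C)CC[C@@H]1CCC[C@H](c2ccccc2)C1` gives 14 nM in this assay, and a 12-fold lower number from compound 1 to compound 2 (1.08 log units; beyond the scatter). Compound 3 `NCC[C@@H]1CCC[C@@H](c2ccccc2)C1` differs from compound 1 only in configuration: the two compounds have the same atoms and bonds and differ only in configuration as drawn: 1 of 2 stereo elements differ; a stereocentre at a saturated ring carbon is drawn S in compound 1 and R in compound 3. Among the compounds with values here, no measured step concerns a change of configuration; the single step known changes the amine instead, so it gives no guidance here. For compound 3 the estimate is therefore centred close to compound 1, with a wide range, expected at 200 nM (from 50 nM to 800 nM), meaning an expected step of a 1.2-fold higher number from compound 1 to compound 3 (0.08 log units; within the scatter).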

Compound 3, inhibition constant: 43 nM
For compound 3 the middle estimate is 4.7-fold (0.67 log units) above the measured one, and the stated range ends above it.
By their numbers in this assay, from the lowest: compound 2; then compound 3; then compound 1.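

Configuration alone can shift the number in this assay: drawing the saturated ring carbon R rather than S gives a 3.9-fold lower number from compound 1 to compound 3 (0.59 log units; beyond the scatter). Before this, only a change of the amine had been seen to move the number, whereas here the step can be assigned to this one stereocentre because no atom or bond changes: the fact that compounds 1 and 3 differ only in the configuration as drawn

Still open, going by these compounds, is whether the dimethylamino group of compound 2 gives a similar step when this ring carbon is drawn R. Also open is whether turning the other stereocentre, or using a longer chain to carry the amine, moves the number too.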